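Chloro in Place of Iodo on a Shared Core

This account rests on a few compounds, and the source may have more. Where it says the series, first, only, none or still open, it means among the compounds named here.

Compound 1 `CC(C)[C@H]1CC[C@@]2(CO2)[C@H]2C(=O)OCC(C(=O)O)=C[C@H]12` gives 210 nM in a functional assay on HCT-116 cells (Homo sapiens) for inhibition, with a stated time of 72 h; a higher number here means a weaker inhibitor, a lower number a stronger inhibitor.
Compound 2 `CC(C)[C@H]1CC[C@@](O)(CO)[C@H]2C(=O)OCC(C(=O)O)=C[C@H]12` gives only a limit, > 32000 nM, in this assay.
Compound 3 `CC(C)[C@H]1CC[C@@](O)(CI)[C@H]2C(=O)OCC(C(=O)O)=C[C@H]12` gives 2140 nM in this assay.

Among the two real numbers, compound 3 stands highest, so it is the weaker inhibitor of the pair; compound 1 sits at a clearly lower number, beyond the scatter. The value for compound 2 is a limit of the assay and not a number (the limit of > 32000 nM in this assay, at which 1 of the 3 values shown sits).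

Compound 4 `CC(C)[C@H]1CC[C@@](O)(CCl)[C@H]2C(=O)OCC(C(=O)O)=C[C@H]12` differs from compound 3 in one place: chloro in place of iodo on a saturated chain carbon bound to a saturated ring carbon. Among the compounds with values here, only one measured step touches this position, namely an at least 14-fold lower number from compound 2 to compound 3 (1.17 log units; beyond the scatter), a large gain that came with the move from hydroxy to iodo. Chloro is a smaller halogen than iodo, and no measured compound carries it, so its effect can only be bracketed between the hydroxy and the iodo results. The expected outcome is a moderately higher number, a 2.3-fold higher number from compound 3 to compound 4 (0.37 log units; beyond the scatter), well short of the limit seen for compound 2. Compound 4 is therefore estimated at 5000 nM in this assay, within 1500 nM to 20000 nM.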

Compound 4, half-maximal inhibitory concentration: 220 nM
The estimate for compound 4 lay 23-fold (1.36 log units) above the measured number; measured number outside the range, below it.
By their numbers in this assay, from the lowest: compounds 1 and 4 (each within the scatter of the next); then compound 3. At a limit, above all of these: compound 2.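

The earlier compounds shown here showed only that iodo on this carbon gives a far lower number than hydroxy; the new result shows that the choice of halogen matters too, with a 9.7-fold lower number from compound 3 to compound 4 (0.99 log units; beyond the scatter) in this assay. Set against the hydroxy compound, the change gives an at least 140-fold lower number from compound 2 to compound 4 (2.16 log units; beyond the scatter), so the chloromethyl group is the better of the three groups compared at this position. The true size of that second step stays unknown, since the value for compound 2 is a limit of the assay and not a number: the limit of > 32000 nM in this assay, at which 1 of the 4 values shown sits.

On these data alone, whether bromo, fluoro or an amine on this same carbon would also give a low number remains open. The compounds shown also do not tell why chloro and iodo differ so clearly here.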